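A few compounds are considered here, and "the series" means these few. Any claim that something is new, unique, unknown or untested is made for them only; others in the source may bear on it.

Measured so far:
Compound 1, `COc1cc(-c2nc3cc(/C=C4\SC(=O)N(Cc5ccccc5)C4=O)ccc3[nH]2)cc(OC)c1OC`: in a functional assay on MDA-MB-231 cells (Homo sapiens) for inhibition, read by MTT assay, with a stated time of 48 h (a higher number here means a weaker inhibitor, a lower number a stronger inhibitor), compound 1 gives 2290 nM.
Compound 2, `COc1cc(-c2nc3cc(/C=C4\SC(=O)N(Cc5cccc(C)c5)C4=O)ccc3[nH]2)cc(OC)c1OC`: in this assay compound 2 gives 3260 nM.

Within the data shown here, compound 2 stands at one end of these two numbers, with compound 1 as its only neighbour, and a 1.4-fold higher number from compound 1 to compound 2 (0.15 log units; within the scatter), so the two compounds cannot be told apart on this evidence. Compound 3, `COc1cc(CN2C(=O)S/C(=C\c3ccc4[nH]c(-c5cc(OC)c(OC)c(OC)c5)nc4c3)C2=O)cc(OC)c1OC`, differs from compound 2 in one place: 3,4,5-trimethoxyphenyl in place of 3-methylphenyl on a saturated chain carbon bound to an amide-type nitrogen in a ring. Among the measured compounds shown here, the single measured step, a 1.4-fold higher number from compound 1 to compound 2 (0.15 log units; within the scatter), concerns a far smaller alteration in this part of the molecule and offers no direct guide to the trimethoxyphenyl; it shows only that the one change tried there left the number within the scatter. Compound 3 is therefore expected to stay near compound 2, with a 1.1-fold lower number from compound 2 to compound 3 (0.04 log units; within the scatter) and wide uncertainty in both directions. The estimate for compound 3 in this assay is 3000 nM, within a range from 1000 nM to 9000 nM.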

Compound 3, half-maximal inhibitory concentration: 270 nM
For compound 3 the middle estimate is 11-fold (1.05 log units) above the measured one; measured number outside the range, below it.
By their numbers in this assay, from the lowest: compound 3; then compounds 1 and 2 (each within the scatter of the next).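

At this position, on a saturated chain carbon bound to an amide-type nitrogen in a ring, the choice of aromatic group can clearly change the result. In this assay, 3,4,5-trimethoxyphenyl gives a 12-fold lower number from compound 2 to compound 3 (1.08 log units; beyond the scatter) and also an 8.5-fold lower number from compound 1 to compound 3 (0.93 log units; beyond the scatter), making compound 3 the strongest inhibitor of the three, whereas the methyl step alone had shown no change beyond the scatter. Nothing available here explains how the trimethoxyphenyl group produces this gain.

The compounds shown leave open whether all three methoxy groups are needed, or whether a methoxyphenyl group would give a similar number. They also leave open how this position would respond to a phenyl ring carrying an amine or a carboxylic acid.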